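The compounds below may be only part of what the source reports. "The series", "measured", "known", "first", "only" and "open" are said of these compounds alone.

Measured so far:
- compound 1, `CCCCCCCCCCCCCCNC(=O)[C@@H](NC(=O)/C=C/c1ccccc1)[C@@H](C)O`, gives 35800 nM in a functional assay on SiHa cells (Homo sapiens) for cytotoxicity, read by MTT assay, with a stated time of 48 h; on this read-out higher numbers stand for weaker inhibition and lower numbers for stronger inhibition
- compound 2, `CCCCCCCCCCCCCCCCCCNC(=O)[C@@H](NC(=O)c1ccco1)[C@@H](C)O`, gives 13400 nM
- compound 3, `CCCCCCCCCCCCCCCCCCNC(=O)[C@@H](NC(=O)c1cccs1)[C@@H](C)O`, gives 117000 nM

All three share a core in which a long chain is joined through an amide to a threonine-like unit that carries a second amide; they differ in the group on that second carbonyl carbon and in the chain length. Among the measured compounds shown here, compound 3 stands at the highest number of the three, that is, the weakest inhibition; the one step recorded for it, an 8.7-fold higher number from compound 2 to compound 3 (0.94 log units; beyond the scatter), shows how much the thiophene analogue lags behind the furan one.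

Compound 4, `CCCCCCCCCCCCCCCCCCNC(=O)[C@@H](NC(=O)/C=C/c1ccccc1)[C@@H](C)O`, keeps the chain of compound 3 and changes the aromatic part: 2-phenylethenyl in place of thiophen-2-yl on a carbonyl carbon. For the measured compounds named here, no recorded step covers this exact swap. The closest guide is compound 1, which already carries the 2-phenylethenyl group on a shorter chain and gives 35800 nM, a clearly lower number than compound 3. That points to a move down, though the chain length differs and adds uncertainty.

Compound 4 is therefore expected to come in near 35000 nM, within 10000 nM to 120000 nM, a step of a 3.3-fold lower number from compound 3 to compound 4 (0.52 log units; beyond the scatter).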

Compound 4, half-maximal inhibitory concentration: 35900 nM
The estimate for compound 4 lay 1.0-fold (0.01 log units) below the measured number; measured number inside the range.
By their numbers in this assay, from the lowest: compound 2; then compounds 1 and 4 (each within the scatter of the next); then compound 3.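

On the same long chain, the group on the carbonyl carbon can now be compared across three members in this assay, and 2-phenylethenyl falls in the middle of the order, with a 3.3-fold lower number from compound 3 to compound 4 (0.51 log units; beyond the scatter) and a 2.7-fold higher number from compound 2 to compound 4 (0.43 log units; beyond the scatter). Its place in that order shows that the number of heavy atoms alone does not sort these compounds: 2-phenylethenyl is the largest of the three groups, yet the highest and lowest numbers both belong to the smaller five-membered aromatic rings. Among the compounds shown here, the chain can also be judged on its own for the first time, and with a 1.0-fold higher number from compound 1 to compound 4 (0.00 log units; within the scatter) the two numbers cannot be told apart, so butyl in place of hydrogen far along the chain makes no measurable difference when 2-phenylethenyl is present.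

Going by these compounds, whether the chain matters as little with furan-2-yl or thiophen-2-yl remains open, as does the result of placing a plain phenyl or a pyridine ring on the same carbonyl carbon. Nothing shown here accounts for the order of these groups or for why the chain made no measurable difference.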